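Trifluoromethyl for Methoxy on a Cyclopropyl Quinolone Core

The source may hold more compounds than are shown below. What is called first, only, known or untested is meant among the compounds shown, and "the series" means these compounds.

Compound 1 `COc1c(N2CCC(C)(CN)C2)c(F)cc2c(=O)c(C(=O)O)cn(C3CC3)c12` gives 38 ug/mL in a functional assay on V79 cells (Cricetulus griseus) for cytotoxicity, read by colony formation; a higher number here means a weaker inhibitor, a lower number a stronger inhibitor. Compound 2 `CC1(CN)CCN(c2c(F)cc3c(=O)c(C(=O)O)cn(C4CC4)c3c2C(F)(F)F)C1` differs from compound 1 by trifluoromethyl in place of methoxy on an aromatic carbon; in this assay compound 2 gives 110 ug/mL, and the step is a 2.9-fold higher number from compound 1 to compound 2 (0.46 log units; beyond the scatter). Compound 3 `COc1c(N2CCC(C)(N)C2)c(F)cc2c(=O)c(C(=O)O)cn(C3CC3)c12` differs from compound 1 by amino in place of aminomethyl on a saturated ring carbon; in this assay compound 3 gives 38 ug/mL, with no change at the digits printed from compound 1 to compound 3 (within the scatter). Compound 4 `CC1(N)CCN(c2c(F)cc3c(=O)c(C(=O)O)cn(C4CC4)c3c2C(F)(F)F)C1` differs from compound 3 by trifluoromethyl in place of methoxy on an aromatic carbon, the same kind of change as before, the surroundings differing only in that the changed carbon is ortho to a 3-amino-3-methylpyrrolidin-1-yl group rather than a 3-(aminomethyl)-3-methylpyrrolidin-1-yl group. Among the compounds with values here, that single earlier instance, a 2.9-fold higher number from compound 1 to compound 2 (0.46 log units; beyond the scatter), is the only guide. Compound 4 is expected to show a step of a 2.9-fold higher number from compound 3 to compound 4 (0.46 log units; beyond the scatter). Compound 4 is estimated at 110 ug/mL, between 55 ug/mL and 220 ug/mL.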

Compound 4, half-maximal inhibitory concentration: 110 ug/mL
The estimate for compound 4 equals the measured number at the digits printed, within the range that was stated.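

In this assay, trifluoromethyl in place of methoxy gives a 2.9-fold higher number from compound 3 to compound 4 (0.46 log units; beyond the scatter), and the step carries over from one core to the other: the same change on two cores in this assay, a 2.9-fold higher number (0.46 log units; beyond the scatter) from compound 1 to compound 2 and a 2.9-fold higher number (0.46 log units; beyond the scatter) from compound 3 to compound 4, 1.0-fold (0.00 log units) apart, within the scatter of two such steps. Amino in place of aminomethyl gives no change at the digits printed from compound 2 to compound 4 (within the scatter), and this absence of a measurable step also holds on both cores: the same change on two cores in this assay, no change at the digits printed (within the scatter) from compound 1 to compound 3 and no change at the digits printed (within the scatter) from compound 2 to compound 4, 1.0-fold (0.00 log units) apart, within the scatter of two such steps. These two comparisons rest on four compounds in a single assay, so they do not show that either step would hold on other cores, and they give no cause for it.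

The compounds shown leave open what a chloro group or a nitrile would give on that aromatic carbon. They also leave open whether the trifluoromethyl step persists with a piperazine in place of the 3-amino-3-methylpyrrolidin-1-yl group.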